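A few compounds are considered here, and "the series" means these few. Any claim that something is new, unique, unknown or untested is made for them only; others in the source may bear on it.

Measured so far:
compound 1, `O[C@@H]1[C@@H](O)CN[C@H]1c1ccc(-c2ccccc2)cc1`, giving 0.3%
compound 2, `Cc1ccc([C@@H]2NC[C@H](O)[C@H]2O)cc1`, giving 0%
compound 3, `Cc1ccc([C@H]2NC[C@@H](O)[C@@H]2O)cc1`, giving 0%

All three were tested in an assay on isolated protein for inhibition of alpha-galactosidase (Coffea arabica), read by spectrophotometry, tested at 1000 uM; on this read-out lower numbers stand for less inhibition and higher numbers for more inhibition at the one concentration tested (going by the name of the read-out). Compound 2 and compound 3 are mirror images of one another, and this gave no change at the digits printed from compound 2 to compound 3 (within the scatter); the two stand together at the lowest level of the three numbers. Compound 1 differs from compound 2 in one place: phenyl in place of methyl on an aromatic carbon. That step gave a number 0.3 percentage points higher from compound 2 to compound 1 (within the scatter), so none of the three measured compounds shows more than a trace of inhibition at the one concentration tested.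

Compound 4, `O[C@H]1[C@H](O)CN[C@@H]1c1ccc(-c2ccccc2)cc1`, has not yet been measured in this assay. It differs from compound 3 by the same change that separates compound 1 from compound 2: phenyl in place of methyl on an aromatic carbon. The core of compound 4 differs from the core of compound 1 only as follows: the two compounds have the same atoms and bonds and differ only in configuration as drawn: 3 of 3 stereo elements differ (all stereocentres are inverted: mirror images); a stereocentre at a saturated ring carbon is drawn S in compound 2 and R in compound 3; a stereocentre at a saturated ring carbon is drawn S in compound 2 and R in compound 3; a stereocentre at a saturated ring carbon is drawn S in compound 2 and R in compound 3.

Since the same change gave a number 0.3 percentage points higher from compound 2 to compound 1 (within the scatter), and compound 3 gives 0%, the expected step from compound 3 to compound 4 is small, a number 0.5 percentage points higher from compound 3 to compound 4 (within the scatter). Compound 4 is therefore expected to give about 0.5%, most likely between 0% and 8%.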

Compound 4, a percentage reported as inhibition, at one concentration (the size of the read-out at that concentration, not a potency): 0%
Compound 4: middle estimate off by 0.5 percentage points, on the high side, and the stated range covers the measured number.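

In this assay, phenyl in place of methyl gave no change at the digits printed from compound 3 to compound 4 (within the scatter), and inverting all the stereocentres of the biphenyl-bearing compound gave a number 0.3 percentage points lower from compound 1 to compound 4 (within the scatter). The change from methyl to phenyl therefore reads the same on the two mirror-image cores, as far as this read-out can tell: the same change on two cores in this assay, a number 0.3 percentage points higher (within the scatter) from compound 2 to compound 1 and no change at the digits printed (within the scatter) from compound 3 to compound 4, 0.3 percentage points apart, within the scatter of two such steps. Going by these compounds alone, this agreement is weak support for carrying the change from one core to another: all four compounds show no more than a trace of inhibition at the one concentration tested, so it shows only that the change did not bring out measurable inhibition on either core, not that it would act alike on a compound that clearly inhibits the enzyme.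

Still open, going by these compounds, is whether another group in that place, such as an amine, a carboxylic acid or a longer chain, would give inhibition beyond the scatter in this assay. Also open is whether mirror-image partners would part once such inhibition appears, a question this pair cannot settle: the fact that compounds 1 and 4 differ only in the configuration as drawn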